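The source may report more compounds than this note shows. Statements on the series, on what has been measured and on what is new or still open speak of the compounds shown alone.

Compound 1 `COc1cc(-c2nn(-c3cccc(NC(=O)Nc4ccc(Cl)c(Cl)c4)c3)cc2-c2ccncc2)ccc1Cl` is the starting point. In a functional assay on UO-31 cells (Homo sapiens) for inhibition, read by sulforhodamine B assay, with a stated time of 48 h (a lower number here means that less compound is tolerated, a higher number that more compound is tolerated), compound 1 gives > 50000 nM, which is a limit of the assay rather than a measured number; on the numbers shown, compound 1 therefore stands only at a limit, and the one other value shown is a limit as well. Compound 2 `O=C(Nc1cccc(-n2cc(-c3ccncc3)c(-c3ccc(Cl)c(O)c3)n2)c1)Nc1ccc(Cl)c(Cl)c1` is the single close relative, differing by hydrogen in place of methyl on an oxygen on an aromatic ring. In this assay compound 2 gives > 32500 nM, also a limit. The step that the two limits leave unreadable from compound 1 to compound 2 is consequently unreadable, since both ends sit at limits (the limit of > 32500 nM in this assay, at which 1 of the 2 values shown sits, and (the limit of > 50000 nM in this assay, at which 1 of the 2 values shown sits)).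

Compound 3 `COc1cc(-c2nn(-c3cccc(NC(=O)c4ccc(Cl)c(C(F)(F)F)c4)c3)cc2-c2ccncc2)ccc1Cl` differs from compound 1 in another place: 4-chloro-3-(trifluoromethyl)phenyl in place of (3,4-dichlorophenyl)amino on a carbonyl carbon. Within the data shown here, no measured step bears on this change, and the one step measured gives no size at all. Because compound 1 gives > 50000 nM at a limit, the expectation for compound 3 rests on that limit alone: the estimated step of a number no higher from compound 1 to compound 3 (the limit leaves the size open) is none beyond the scatter. Compound 3 is therefore expected to give about 50000 nM in this assay, within the range 20000 nM to 120000 nM.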

Compound 3, concentration lethal to 50% of the cells: > 32500 nM
Compound 3 gave a limit, no number; the forecaster's own chance of this, stated with the estimate: 70%; the middle value lies beyond the limit too.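

In this assay compound 3 gives > 32500 nM, which is a limit and not a number. Among these compounds, compound 1 also stands at a limit, so no step from compound 1 to compound 3 can be read. The compounds shown leave open the actual concentration that reaches the read-out for any of the three compounds, and what size of effect, if any, either structural change has.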